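The compounds below may be only part of what the source reports. "The series", "measured", "known", "first", "only" and "open" are said of these compounds alone.

Three compounds have been measured in a functional assay on SK-N-SH cells (Homo sapiens) for inhibition, read by sulforhodamine B assay, with a stated time of 48 h; on this read-out lower numbers stand for stronger inhibition and higher numbers for weaker inhibition:

Compound 1 `CO[C@@H]1CC=C2NN(c3ccc(Cl)cc3)C(=O)C[C@]2(C)O1` gives 31700 nM.
Compound 2 `CO[C@@H]1CC=C2NN(c3cccnc3)C(=O)C[C@]2(C)O1` gives 19000 nM.
Compound 3 `CO[C@@H]1CC=C2NN(c3ccc(C)cc3)C(=O)C[C@]2(C)O1` gives 25300 nM.

Compound 3 sits among these with its nearest neighbour compound 1, the step of a 1.3-fold lower number from compound 1 to compound 3 (0.10 log units; within the scatter), and with compound 2 on its other side, the step of a 1.3-fold higher number from compound 2 to compound 3 (0.12 log units; within the scatter); both gaps lie within the scatter, so the three numbers are not separated from each other.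

Compound 4 `CO[C@@H]1CC=C2NN(c3cncnc3)C(=O)C[C@]2(C)O1` differs from compound 3 in one place: pyrimidin-5-yl in place of 4-methylphenyl on an amide-type nitrogen in a ring. For the measured compounds named here, two measured steps bear on an exchange of the aryl group on that amide-type nitrogen: a 1.7-fold lower number from compound 1 to compound 2 (0.22 log units; within the scatter) and a 1.3-fold higher number from compound 2 to compound 3 (0.12 log units; within the scatter). Each replaced one aromatic ring by another, one of them bringing in a ring nitrogen, and neither moved the number beyond the scatter. Compound 4 brings a second ring nitrogen into the same position, a change of the same kind but not itself measured, so in this assay no step beyond the scatter is expected, the estimated step being a 1.3-fold lower number from compound 3 to compound 4 (0.10 log units; within the scatter). For compound 4 the expected value in this assay is therefore 20000 nM, within a range of 8000 nM to 50000 nM.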

Compound 4, half-maximal inhibitory concentration: 16600 nM
Estimate against measurement, compound 4: 1.2-fold (0.08 log units) above; low and high end bracket the measured number.
By their numbers in this assay, from the lowest: compounds 4, 2, 3 and 1 (each within the scatter of the next).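

In this assay the pyrimidin-5-yl group on the amide-type nitrogen, which counts 2 hydrogen-bond acceptors where 4-methylphenyl counts none, leaves the number within the scatter of all three earlier aryl groups (a 1.5-fold lower number from compound 3 to compound 4 (0.18 log units; within the scatter); a 1.1-fold lower number from compound 2 to compound 4 (0.06 log units; within the scatter); a 1.9-fold lower number from compound 1 to compound 4 (0.28 log units; within the scatter)). Rings with no ring nitrogen, with one and with two now stand on this nitrogen without any step among the four compounds leaving the scatter, so the count of ring nitrogens has no readable effect on this read-out. Nothing available accounts for this lack of separation.

As far as these compounds go, it remains open whether a group other than a six-membered aromatic ring on this nitrogen, such as a longer alkyl chain or a benzyl group, would separate from these numbers. The same holds for an aromatic ring carrying an amine or a carboxylic acid.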